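Working notes: methylsulfonyl in place of chloro

The compounds below may be only part of what the source reports. "The series", "measured", "known", "first", "only" and "open" are said of these compounds alone.

compound 1 `CC(Cl)/C=C/C(=O)N(Cc1ccc(C#N)cc1)CC(C)C`: 158 nM
compound 2 `CC(Cl)/C=C/C(=O)N(Cc1ccc(Cl)cc1)CC(C)C`: 251 nM
compound 3 `CC(Cl)/C=C/C(=O)N(Cc1ccc(S(C)(=O)=O)cc1)CC(C)C`: not yet measured

Within the data shown here, in a functional assay on the whole organism for inhibition, with Gossypium hirsutum as the target (on this read-out lower numbers stand for stronger inhibition and higher numbers for weaker inhibition), compound 2 gives 251 nM, which lies within the scatter of the only other number. Compound 3 brings methylsulfonyl in place of chloro on an aromatic carbon, para to a large group. Among the measured compounds shown here, the only measured step that bears on this change is also an exchange on an aromatic carbon, chloro in place of cyano, and it is a 1.6-fold higher number from compound 1 to compound 2 (0.20 log units; within the scatter). For the measured compounds named here, no measurement yet shows what methylsulfonyl does, so this single step is a thin guide. No change beyond the scatter is expected in this assay, in either direction. The estimated step is a 1.3-fold lower number from compound 2 to compound 3 (0.10 log units; within the scatter). For compound 3 the expected value is 200 nM, with an estimated range of 70 nM to 600 nM.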

Compound 3, half-maximal inhibitory concentration: 63100 nM
Compound 3: the middle estimate sits 320-fold (2.50 log units) below what was measured; measured number outside the range, above it.
By their numbers in this assay, from the lowest: compounds 1 and 2 (each within the scatter of the next); then compound 3.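

Working notes, continued: in this assay this place on the aromatic ring is not indifferent to its substituent, since methylsulfonyl in place of chloro gives a 250-fold higher number from compound 2 to compound 3 (2.40 log units; beyond the scatter) and methylsulfonyl in place of cyano gives a 400-fold higher number from compound 1 to compound 3 (2.60 log units; beyond the scatter) as well. The exchange of cyano and chloro, a 1.6-fold higher number from compound 1 to compound 2 (0.20 log units; within the scatter) and so within the scatter, therefore did not mark the limit of what this place accepts, and it gave no guide to methylsulfonyl. The data offer no explanation for the large rise in the number.

Going by these compounds, it remains open whether a methylthio group or a sulfonamide at this same place would read like compound 1 and compound 2 or like compound 3. On these data alone, it is also open whether the effect of methylsulfonyl would persist with a longer chain on the amide nitrogen.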